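Swapping methoxyphenyl for dichlorophenyl in a cytotoxicity series

The source may hold more compounds than are shown below. What is called first, only, known or untested is meant among the compounds shown, and "the series" means these compounds.

In a functional assay on HeLa cells (Homo sapiens) for cytotoxicity, with a stated time of 72 h (a lower number here means a stronger inhibitor, a higher number a weaker inhibitor), compound 2 `COc1ccc(-c2nc3sc(Cc4ccc(Cl)cc4)nn3c2Br)cc1` gives 66000 nM. It is the only numerical result in this assay among the two measured compounds. Compound 1 `Fc1ccc(-c2nc3sc(Cc4ccc(Cl)cc4)nn3c2Br)cc1` gives only a limit, > 250000 nM, in this assay. Within the data shown here, the single measured step, an at least 3.7-fold lower number from compound 1 to compound 2 (0.57 log units; beyond the scatter), is the sole guide, and it rests on a limit, (the limit of > 250000 nM in this assay, at which 1 of the 2 values shown sits). Compound 3 `Clc1ccc(Cc2nn3c(Br)c(-c4ccc(Cl)cc4Cl)nc3s2)cc1` carries 2,4-dichlorophenyl in place of 4-methoxyphenyl on an aromatic carbon. This change removes the methoxy that distinguished compound 2 from compound 1 and brings halogens onto that ring, as in compound 1, so the measured step bears on it only by analogy and in reverse. A higher number in this assay is therefore expected, possibly back toward a limit. Compound 3 is estimated at 150000 nM in this assay, within 40000 nM to 250000 nM. This estimate means a 2.3-fold higher number from compound 2 to compound 3 (0.36 log units; beyond the scatter).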

Compound 3, half-maximal inhibitory concentration: 118000 nM
The estimate for compound 3 lay 1.3-fold (0.10 log units) above the measured number, and the stated range covers the measured number.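

In this assay, a 1.8-fold higher number from compound 2 to compound 3 (0.25 log units; within the scatter) is all that separates 2,4-dichlorophenyl from 4-methoxyphenyl on this aromatic carbon, so the two groups cannot be told apart here. A measured number at this position therefore does not require the methoxy: with an at least 2.1-fold lower number from compound 1 to compound 3 (0.32 log units; beyond the scatter), a ring bearing two chlorines and no hydrogen-bond acceptor also stands clear of the 4-fluorophenyl ring. Compound 1 gives a limit and not a number, so that step fixes only a minimum size: the limit of > 250000 nM in this assay, at which 1 of the 3 values shown sits.

Going by these compounds, whether a single chlorine on this ring would serve as well as two, or whether an amine or a carboxylic acid there would shift the number, stays open. So does the part played by the bromo group on the shared core.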